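The source may hold more compounds than are shown below. What is called first, only, known or untested is meant among the compounds shown, and "the series" means these compounds.

Compound 2 (`CCCc1ncn2c(O)nncc12`) was tested in a functional assay for inhibition, with Homo sapiens as the target; a higher number here means a weaker inhibitor, a lower number a stronger inhibitor. For compound 2 this assay reports only a limit, > 48000 nM, rather than a number. Compound 1 (`C=CCSc1nncc2c(CC)ncn12`) likewise yields only a limit in this assay, > 48000 nM. Both results sit at the limit of > 48000 nM in this assay, at which 2 of the 2 values shown sit, so compound 2 stands at that limit with no measured number beneath it. Compound 3 (`CCc1ncn2c(O)nncc12`) differs from compound 2 by hydrogen in place of methyl on a saturated chain carbon, two bonds along the chain from an aromatic carbon. Within the data shown here, no measured step of this kind exists, so no shift beyond the scatter is expected. The expected step is a step that the limit leaves unreadable from compound 2 to compound 3. Compound 3 is estimated at 60000 nM, between 20000 nM and 200000 nM.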

Compound 3, half-maximal inhibitory concentration: > 48000 nM
Compound 3 gave a limit, no number; the forecaster's own chance of this, stated with the estimate: 85%; the middle value is on the limit's open side.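

Compound 1, compound 2 and compound 3 each give only a limit in this assay, so no step among them can be read: the limit of > 48000 nM in this assay, at which 3 of the 3 values shown sit.

As far as these compounds go, whether hydrogen in place of methyl, or hydroxy in place of allylsulfanyl, changes inhibition at all stays open.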